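The source may report more compounds than this note shows. Statements on the series, on what has been measured and on what is new or still open speak of the compounds shown alone.

Working notes on the series. In a functional assay on A549 cells (Homo sapiens) for antiproliferative activity, read by MTT assay (on this read-out lower numbers stand for stronger inhibition and higher numbers for weaker inhibition), compound 1 (`COc1cc2c(Oc3ccc(NC(=O)Nc4ccccc4Cl)cc3)ccnc2cc1OCCCCCCC(=O)NO`) gives 1910 nM. Compound 2 (`COc1cc2c(Oc3ccc(NC(=O)N/N=C/c4ccccc4F)cc3)ccnc2cc1OCCCCCCC(=O)NO`) gives 7780 nM, the higher of the two numbers and so the weaker inhibition. Compound 3 (`COc1cc2c(Oc3ccc(NC(=O)NNC(=O)c4cccc(C)c4)cc3)ccnc2cc1OCCCCCCC(=O)NO`) has not been measured. Its difference from compound 2 is this: a group of 10 heavy atoms (8 carbon, 1 nitrogen, 1 oxygen; one six-membered aromatic ring of carbon only) in place of a group of 9 heavy atoms (7 carbon, 1 nitrogen, 1 fluorine; one six-membered aromatic ring of carbon only), on an amide-type nitrogen. Within the data shown here, the entering ((3-methylphenyl)carbonyl)amino group sits on an amide-type nitrogen, the same place that changed in the one measured step, a 4.1-fold higher number from compound 1 to compound 2 (0.61 log units; beyond the scatter). Among the measured compounds shown here, that modest step is the only guide, and the entering group has no measured precedent. A step no larger than that one is therefore expected in this assay, with a slight lean to a lower number and most likely nothing beyond the scatter. The expected step is a 1.6-fold lower number from compound 2 to compound 3 (0.19 log units; within the scatter). For compound 3 the estimated value is 5000 nM, with an expected range of 1800 nM to 14000 nM.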

Compound 3, half-maximal inhibitory concentration: 8190 nM
Beside the measured number, compound 3's estimate is 1.6-fold (0.21 log units) below it; measured number inside the range.
By their numbers in this assay, from the lowest: compound 1; then compounds 2 and 3 (each within the scatter of the next).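

In this assay, ((3-methylphenyl)carbonyl)amino on this amide-type nitrogen gives a 1.1-fold higher number from compound 2 to compound 3 (0.02 log units; within the scatter), so a group carrying a hydrogen-bond donor and a group with none read alike here, within the scatter. Both groups stand apart from 2-chlorophenyl at this position: a 4.3-fold higher number from compound 1 to compound 3 (0.63 log units; beyond the scatter) sits alongside a 4.1-fold higher number from compound 1 to compound 2 (0.61 log units; beyond the scatter), which shows that the gap to compound 1 is shared by two different replacements rather than confined to compound 2. No available evidence bears on why the numbers fall this way.

The compounds shown leave open whether the lower number of compound 1 belongs to the chlorine atom or to the phenyl ring standing directly on this nitrogen. A plain phenyl group, a 2-fluorophenyl group or a small methyl group at this position would separate those readings.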